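Removing the chloro from compound 1: cytotoxicity expectation

The source may report more compounds than this note shows. Statements on the series, on what has been measured and on what is new or still open speak of the compounds shown alone.

Two members of the series have been run in an ADME assay on HCT-116 cells (Homo sapiens) for cytotoxicity, read by MTT assay, with a stated time of 48 h, tested at 2 uM; a lower number here means a weaker effect, a higher number a stronger effect of the compound at the concentration tested. Compound 1 `O=C1C(=O)N(CC(CO)NCCNc2ccnc3cc(Cl)ccc23)c2ccc(Cl)cc21` gives -11% and stands lowest of the two numbers shown. Going by the values given here, compound 2 `O=C1C(=O)N(CC(CO)NCCCCNc2ccnc3cc(Cl)ccc23)c2ccc(F)cc21`, which carries fluoro in place of chloro on the same ring position and a four-carbon linker between the two amine nitrogens, gives 0% in this assay; no single-point step joins it to compound 1, so the pair only shows that compound 2 sits higher, by a gap beyond the usual scatter, while both numbers lie at the bottom of the read-out window where little effect is registered.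

Compound 3 `O=C1C(=O)N(CC(CO)NCCNc2ccnc3cc(Cl)ccc23)c2ccccc21` is the next point. Relative to compound 1 the change is hydrogen in place of chloro on an aromatic carbon. Neither measured compound shows a meaningful effect at the test concentration, and removing a single chlorine from the fused core gives no reason to expect one; the step from compound 1 is expected to be a number 7 percentage points higher from compound 1 to compound 3 (within the scatter), that is, nothing beyond the scatter in either direction. Compound 3 is estimated at -4% in this assay, within -20% to 12%.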

Compound 3, a percentage reported as inhibition, at one concentration (the size of the read-out at that concentration, not a potency): 2%
For compound 3 the middle estimate is 6 percentage points below the measured one; measured number inside the range.
By their numbers in this assay, from the lowest: compound 1; then compounds 2 and 3 (each within the scatter of the next).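

Hydrogen in place of chloro on this aromatic carbon, meta to a fused ring and para to a fused ring, gives the first single-place step in the series: in this assay, a number 13 percentage points higher from compound 1 to compound 3 (beyond the scatter). The position is therefore not silent in this read-out, although the step is modest, and compound 3 at 2% still registers little effect at the concentration tested, so the loss of chloro does not bring out any appreciable cytotoxicity. Nothing available on the series bears on what lies behind this shift.

Open, on these data alone, is whether the shift belongs to chloro itself or would appear with other groups on the same aromatic carbon, such as a methoxy group, a nitrile or an amine, and whether any of these would lift the number clearly above the bottom of the read-out. Also open, as far as these compounds go, is whether a longer chain in the linker of compound 3, changed alone with the ring left free of chloro, would move the number in this assay at all.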